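The source may hold more compounds than are shown below. What is called first, only, known or untested is meant among the compounds shown, and "the series" means these compounds.

Working notes on the series. In a functional assay on Jurkat cells (Homo sapiens) for activation, with a stated time of 24 h (a higher number here means that more compound is needed for the effect, a lower number that less compound is needed), compound 2, `CCOc1ccc(-c2ccc(NCc3ccccc3O)cc2)cc1`, gives 520 nM; this is the only numerical value in this assay across the compounds shown. Compound 1, `N#Cc1ccc(-c2ccc(NCc3ccccc3O)cc2)cc1`, is recorded in this assay as "not active" (no number reported), with no number attached, so nothing can be said about the size of any step between compound 1 and compound 2. Compound 3, `CCSc1ccc(-c2ccc(NCc3ccccc3O)cc2)cc1`, has not yet been measured. The change from compound 2 to compound 3 is ethylsulfanyl in place of ethoxy on an aromatic carbon. Among the compounds with values here, no step between measured compounds exists in this assay, so the expectation for compound 3 rests only on compound 2 and on the structural change itself. The step from compound 2 to compound 3 in this assay is expected to be small, a 1.2-fold lower number from compound 2 to compound 3 (0.06 log units; within the scatter), not clearly beyond the usual scatter in either direction. Compound 3 is therefore estimated at 450 nM in this assay, within a range from 180 nM to 1200 nM.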

Compound 3, half-maximal effective concentration: 1980 nM
The estimate for compound 3 lay 4.4-fold (0.64 log units) below the measured number; the whole stated range lies below it.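

In this assay, within the data shown here, ethylsulfanyl in place of ethoxy on the aromatic carbon para to a large group gives a 3.8-fold higher number from compound 2 to compound 3 (0.58 log units; beyond the scatter) and thus the first readable step: more compound is needed for the effect with sulfur in place of oxygen, at an equal count of heavy atoms. This position is therefore not indifferent to the exchange, yet compound 3 still gives a number, whereas compound 1, with nitrile at the same place, is recorded as "not active" (no number reported) and so its steps to the other compounds cannot be read. No measurement is available that bears on the reason for this step.

From the compounds shown here alone, whether the shift belongs to sulfur alone or to any departure from ethoxy remains open. The compounds shown do not tell how an amine, a carboxylic acid or a longer chain such as propoxy would behave at this position.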